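Methoxy on the Benzyl Arm: A Small Change Ahead

The source may hold more compounds than are shown below. What is called first, only, known or untested is meant among the compounds shown, and "the series" means these compounds.

Measured so far:
Compound 1, `CCN1CCN(CC(=O)Nc2ccc(-c3nc(-c4ccccc4)c(-c4ccccc4)n3C)cc2)CC1`: 46.3%
Compound 2, `Cn1c(-c2ccc(NC(=O)CN3CCN(Cc4ccccc4)CC3)cc2)nc(-c2ccccc2)c1-c1ccccc1`: 49.5%

In a functional assay on MCF7 cells (Homo sapiens) for cytotoxicity, read by MTT assay, with a stated time of 24 h, tested at 80 ug/mL (a higher number here means a stronger effect of the compound at the concentration tested, a lower number a weaker effect), compound 1 gives 46.3%, and compound 2 gives 49.5%. Compound 2 carries the higher of the two numbers, but the step of a number 3.2 percentage points higher from compound 1 to compound 2 (within the scatter) lies within the scatter of repeated measurements, so the two compounds cannot be told apart on this evidence.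

Compound 3, `COc1ccc(CN2CCN(CC(=O)Nc3ccc(-c4nc(-c5ccccc5)c(-c5ccccc5)n4C)cc3)CC2)cc1`, has not yet been measured. It differs from compound 2 by methoxy in place of hydrogen on an aromatic carbon. Among the measured compounds shown here, the only measured step, a number 3.2 percentage points higher from compound 1 to compound 2 (within the scatter), concerns a phenyl in place of methyl on a saturated chain carbon bound to an amine nitrogen in a ring, and it did not move the number beyond the scatter. For the measured compounds named here, no measured step touches an aromatic carbon. With nothing pointing either way, the expected step of a number 0.5 percentage points lower from compound 2 to compound 3 (within the scatter) is none beyond the scatter. Compound 3 is therefore estimated at 49%, with a range from 37% to 61%.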

Compound 3, a percentage reported as activity, at one concentration (the size of the read-out at that concentration, not a potency): 34.5%
Estimate against measurement, compound 3: 14.5 percentage points above; measured number outside the range, below it.
By their numbers in this assay, from the lowest: compound 3; then compounds 1 and 2 (each within the scatter of the next).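

In this assay the ring of the benzyl arm turns out not to be a silent place: methoxy in place of hydrogen on an aromatic carbon, para to a large group, gives a number 15 percentage points lower from compound 2 to compound 3 (beyond the scatter) and so moves the number beyond the scatter, which the change from methyl to phenyl did not do. The step of a number 11.8 percentage points lower from compound 1 to compound 3 (beyond the scatter) agrees, since 4-methoxyphenyl in place of methyl also lands beyond the scatter, while phenyl alone did not. No measured evidence here explains this fall.

Whether it belongs to methoxy in particular stays open, since the compounds shown carry no other group on this ring, such as a fluorine, a hydroxyl or an amine, and no methoxy on another ring carbon. A reading at a single concentration also leaves their potencies open.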